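Removing the Methoxy from Compound 3

A few compounds are considered here, and "the series" means these few. Any claim that something is new, unique, unknown or untested is made for them only; others in the source may bear on it.

Of the three compounds measured in an in vitro functional assay on cells for agonist activity at Bombesin receptor subtype-3 (Homo sapiens), read by luminescence and calcium flux (a lower number here means that less compound is needed, a higher number that more compound is needed for the effect), compound 3 `COc1ccccc1Cc1cnc(CCc2ccc(-c3ccccc3C(=O)O)cc2)[nH]1` gives 1720 nM, the highest number of the set. Compound 1 `O=C(O)c1ccccc1-c1ccc(CCc2ncc(CC3CCCCC3)[nH]2)cc1` gives 41 nM and compound 2 `O=C(O)c1ccccc1-c1ccc(CCc2ncc(CC3CCCC3)[nH]2)cc1` gives 133 nM. The steps of a 42-fold higher number from compound 1 to compound 3 (1.62 log units; beyond the scatter) and a 13-fold higher number from compound 2 to compound 3 (1.11 log units; beyond the scatter) both replace a saturated ring with the 2-methoxyphenyl group, while a 3.2-fold higher number from compound 1 to compound 2 (0.51 log units; beyond the scatter) is modest. Compound 4 `O=C(O)c1ccccc1-c1ccc(CCc2ncc(Cc3ccccc3)[nH]2)cc1` differs from compound 3 by hydrogen in place of methoxy on an aromatic carbon. Among the measured compounds shown here, no measured step removes a methoxy, so the known steps show only that the group at this position matters, not what the methoxy alone contributes. Compound 4 is therefore expected to give 700 nM, with a range from 150 nM to 3000 nM. The estimated step of a 2.5-fold lower number from compound 3 to compound 4 (0.39 log units; beyond the scatter) is expected to be modest and uncertain in direction.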

Compound 4, half-maximal effective concentration: 205 nM
The estimate for compound 4 lay 3.4-fold (0.53 log units) above the measured number; the range from low to high includes it.
By their numbers in this assay, from the lowest: compound 1; then compounds 2 and 4 (each within the scatter of the next); then compound 3.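

Hydrogen in place of methoxy gives an 8.4-fold lower number from compound 3 to compound 4 (0.92 log units; beyond the scatter), so much of the earlier gap to the saturated rings goes with the methoxy and not with the aromatic ring as such. Phenyl in place of cyclopentyl gives a 1.5-fold higher number from compound 2 to compound 4 (0.19 log units; within the scatter), while phenyl in place of cyclohexyl still gives a 5.0-fold higher number from compound 1 to compound 4 (0.70 log units; beyond the scatter), so cyclohexyl keeps a modest edge. Nothing available here explains the effect of the methoxy. As far as these compounds go, whether a hydroxyl or a chlorine on this aromatic carbon, ortho to a large group, would track hydrogen or methoxy stays open. So does the effect of a methoxy placed elsewhere on this ring.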